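Removing the hydroxymethyl from a piperidine ether series

The compounds below may be only part of what the source reports. "The series", "measured", "known", "first", "only" and "open" are said of these compounds alone.

The three measured compounds share one core and differ only in the group on the saturated chain carbon bound to the amine nitrogen in the ring. In an assay on isolated protein for activation of cGMP-dependent protein kinase 1 (Homo sapiens), read by ADP-Glo, with stated times of 120 min and 40 min (a lower number here means that less compound is needed, a higher number that more compound is needed for the effect), compound 1 `OC[C@@H](O[C@H]1CCCN(Cc2ncc[nH]2)[C@H]1c1ccccc1)c1cc(Cl)cc(Cl)c1` gives 7000 nM, compound 3 `OC[C@@H](O[C@H]1CCCN(Cc2cccc3nonc23)[C@H]1c1ccccc1)c1cc(Cl)cc(Cl)c1` gives 8000 nM, and compound 2 `O=C(O)c1ccc(CN2CCC[C@H](O[C@H](CO)c3cc(Cl)cc(Cl)c3)[C@@H]2c2ccccc2)cc1` gives 11000 nM, the highest of the three numbers, though a 1.6-fold higher number from compound 1 to compound 2 (0.20 log units; within the scatter) and a 1.4-fold lower number from compound 2 to compound 3 (0.14 log units; within the scatter), like a 1.1-fold higher number from compound 1 to compound 3 (0.06 log units; within the scatter), sit within the scatter. Compound 4 `O=C(O)c1ccc(CN2CCC[C@H](OCc3cc(Cl)cc(Cl)c3)[C@@H]2c2ccccc2)cc1` departs from compound 2 elsewhere: hydrogen in place of hydroxymethyl on a saturated chain carbon bound to an aromatic carbon and an oxygen on a saturated carbon. Among the compounds with values here, none of the measured steps touches this position, so no measured step bears directly on it. Compound 4 is therefore expected to land near compound 2, with a 1.4-fold higher number from compound 2 to compound 4 (0.13 log units; within the scatter) as the estimated step, giving an estimate of 15000 nM within 5000 nM to 50000 nM.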

Compound 4, half-maximal effective concentration: 76000 nM
For compound 4 the middle estimate is 5.1-fold (0.70 log units) below the measured one; the measured number lies above the stated range.
By their numbers in this assay, from the lowest: compounds 1, 3 and 2 (each within the scatter of the next); then compound 4.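

In this assay, this is the only step shown that lies beyond the scatter: hydrogen in place of hydroxymethyl gives a 6.9-fold higher number from compound 2 to compound 4 (0.84 log units; beyond the scatter), whereas the group varied among compound 1, compound 2 and compound 3 left the numbers within the scatter. The carbon bound to an aromatic carbon and an oxygen on a saturated carbon is thus a position where a change registers in this series. Nothing available explains the size of this step.

Still open, from the compounds shown here alone, is whether a methyl, an aminomethyl or a longer chain at this carbon would bring the number back towards that of compound 2. Also open, going by these compounds, is whether removing hydroxymethyl has a similar effect with the 1H-imidazol-2-yl group of compound 1.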